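The source may report more compounds than this note shows. Statements on the series, on what has been measured and on what is new or still open speak of the compounds shown alone.

Compound 1 `N[C@]1(C(=O)O)[C@H]2[C@@H](C[C@H]1OCc1cccc(Br)c1)[C@]2(F)C(=O)O` serves as the reference. Among the compounds with values here, in an assay on CHO cells for binding affinity to metabotropic glutamate receptor 2 (Rattus norvegicus) (a higher number here means a weaker inhibitor, a lower number a stronger inhibitor), compound 1 gives 4.71 nM, the lowest of the two numbers measured so far. Its nearest neighbour, compound 2 `N[C@]1(C(=O)O)[C@H]2[C@@H](C[C@H]1OCc1cccc([N+](=O)[O-])c1)[C@]2(F)C(=O)O`, gives 7.87 nM in this assay, the step being a 1.7-fold higher number from compound 1 to compound 2 (0.22 log units; within the scatter), a nitro in place of bromo on an aromatic carbon. Compound 3 `N[C@]1(C(=O)O)[C@H]2[C@@H](C[C@H]1OCc1c(F)cccc1F)[C@]2(F)C(=O)O` differs from compound 1 by 2,6-difluorophenyl in place of 3-bromophenyl on a saturated chain carbon bound to an oxygen on a saturated carbon. Within the data shown here, no measured step exchanges one phenyl substitution pattern for another, so the only guidance is a 1.7-fold higher number from compound 1 to compound 2 (0.22 log units; within the scatter), which shows that replacing one group on that ring by another left the number within the scatter. On that basis little movement is expected, with at most a slight lean toward a higher number in this assay, estimated as a 1.9-fold higher number from compound 1 to compound 3 (0.28 log units; within the scatter). Compound 3 is therefore expected to give 9 nM in this assay, within a range from 3 nM to 30 nM.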

Compound 3, inhibition constant: 7.02 nM
Compound 3: middle estimate off by 1.3-fold (0.11 log units), on the high side; the range from low to high includes it.
By their numbers in this assay, from the lowest: compounds 1, 3 and 2 (each within the scatter of the next).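

In this assay, the exchange of 3-bromophenyl for 2,6-difluorophenyl gives a 1.5-fold higher number from compound 1 to compound 3 (0.17 log units; within the scatter) and so stays within the scatter. The earlier step changed only the group carried on the ring, whereas this one changes both the groups and their substitution pattern, showing that at this position on a saturated chain carbon bound to an oxygen on a saturated carbon, a change of pattern also leaves the number within the scatter. No measurement is available that bears on why the number holds here.

As far as these compounds go, all three compounds keep a substituted phenyl ring at this position, so it remains open whether a pyridine ring, a naphthyl group or a plain alkyl chain would be accepted as well. From the compounds shown here alone, an amine or a carboxylic acid on the phenyl ring is equally open.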